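Cytotoxicity Estimate for a Dimethylphenyl Analogue

The source may hold more compounds than are shown below. What is called first, only, known or untested is meant among the compounds shown, and "the series" means these compounds.

Compound 1, `Cc1ccccc1-c1cc(C)c(Nc2ccnc(Nc3ccc(C#N)cc3)n2)c(C)c1`, gives 3820 nM in an ADME assay on MT4 cells (Homo sapiens) for cytotoxicity, read by MTT assay, with a stated time of 4 days; on this read-out higher numbers stand for lower toxicity in this test and lower numbers for higher toxicity in this test. Compound 2, `Cc1cc(-c2cc(Cl)cc(Cl)c2)cc(C)c1Nc1ccnc(Nc2ccc(C#N)cc2)n1`, gives 4290 nM. Compound 3, `Cc1cc(-c2ccccc2F)cc(C)c1Nc1ccnc(Nc2ccc(C#N)cc2)n1`, gives 2120 nM.

Compound 3 gives the lowest of the three numbers, which on this read-out means the highest toxicity among them. Against compound 1 the step is a 1.8-fold lower number from compound 1 to compound 3 (0.26 log units; within the scatter), so the two cannot be told apart. Against compound 2 the step is a 2.0-fold lower number from compound 2 to compound 3 (0.31 log units; beyond the scatter), a modest but real difference.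

Compound 4, `Cc1cc(-c2c(C)cccc2C)cc(C)c1Nc1ccnc(Nc2ccc(C#N)cc2)n1`, differs from compound 3 by 2,6-dimethylphenyl in place of 2-fluorophenyl on an aromatic carbon. The measured step that comes closest to this change is a 1.8-fold lower number from compound 1 to compound 3 (0.26 log units; within the scatter), which swapped a methyl for a fluoro on the same ring and stayed within the scatter. Compound 4 carries two methyl groups on that ring, so the change runs back in the direction of compound 1 and one step further. The other aryl swap, a 1.1-fold higher number from compound 1 to compound 2 (0.05 log units; within the scatter), also changed little. The expectation is therefore a small rise in the number, a 1.7-fold higher number from compound 3 to compound 4 (0.22 log units; within the scatter), possibly within the scatter. Compound 4 is estimated at 3500 nM, with a range from 1800 nM to 7000 nM.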

Compound 4, half-maximal cytotoxic concentration: 2590 nM
The estimate for compound 4 lay 1.4-fold (0.13 log units) above the measured number; the measured number falls inside the stated range.
By their numbers in this assay, from the lowest: compounds 3, 4, 1 and 2 (each within the scatter of the next, the first and the last beyond it).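

In this assay, exchanging 2-fluorophenyl for 2,6-dimethylphenyl at this position, a change from 7 heavy atoms to 8 on a ring of the same kind, leaves the number within the scatter (a 1.2-fold higher number from compound 3 to compound 4 (0.09 log units; within the scatter)). Methyl in place of hydrogen on the aryl ring of compound 1 also stays within the scatter (a 1.5-fold lower number from compound 1 to compound 4 (0.17 log units; within the scatter)), as does the exchange of 3,5-dichlorophenyl for 2,6-dimethylphenyl (a 1.7-fold lower number from compound 2 to compound 4 (0.22 log units; within the scatter)), so compound 4 cannot be told apart from any of the other three compounds. At this position, then, compound 4 adds a third aryl exchange that makes no clear difference, and the pair of compound 2 and compound 3 remains the only one that lies beyond the scatter.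

Nothing among the data given accounts for why these numbers lie so close together. The aryl groups shown carry only methyl, fluoro or chloro groups, so it remains open whether an aryl ring bearing an amine or a carboxylic acid, or a longer chain at this position, would give a number clearly apart from these.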